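Adding a Second Chlorine to Compound 2

The source may hold more compounds than are shown below. What is called first, only, known or untested is meant among the compounds shown, and "the series" means these compounds.

Compound 1 `O=C(Nc1cccc(Cl)c1)C(Cl)Cl` and compound 2 `O=C(Nc1ccc(Cl)cc1)C(Cl)Cl` share one core and differ only in the placement of a single chloro group. In a functional assay on A549 cells (Homo sapiens) for antiproliferative activity, read by MTT assay, with a stated time of 72 h (on this read-out higher numbers stand for weaker inhibition and lower numbers for stronger inhibition), compound 1 gives 14800 nM, and compound 2 gives 20400 nM. Compound 2 thus stands together with compound 1, the gap between them lying within the scatter, so neither is separated from the other. Compound 3 `O=C(Nc1ccc(Cl)c(Cl)c1)C(Cl)Cl` differs from compound 2 by chloro in place of hydrogen on an aromatic carbon. Within the data shown here, no comparable step between measured compounds is available, so its size is open. Compound 3 is expected to show a modest step toward a lower number in this assay, namely a 1.7-fold lower number from compound 2 to compound 3 (0.23 log units; within the scatter). The estimate for compound 3 is 12000 nM, with a range from 4000 nM to 35000 nM.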

Compound 3, half-maximal inhibitory concentration: 5090 nM
The estimate for compound 3 lay 2.4-fold (0.37 log units) above the measured number, within the range that was stated.
By their numbers in this assay, from the lowest: compound 3; then compounds 1 and 2 (each within the scatter of the next).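

Placing a single chloro group differently had left compound 1 and compound 2 within the scatter, whereas chloro in place of hydrogen on the aromatic carbon ortho to a chloro group gives a 4.0-fold lower number from compound 2 to compound 3 (0.60 log units; beyond the scatter) and a 2.9-fold lower number from compound 1 to compound 3 (0.46 log units; beyond the scatter) in this assay as a step beyond it. A second chloro group at this position thus separates compound 3 from both earlier compounds. Nothing measured here accounts for this step. From the compounds shown here alone, whether methyl, methoxy or an amine at this position would give a similar step remains open, as does the effect of a second chloro group elsewhere on the ring.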